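Isopropoxy to methylcarbamoyl on the aromatic ring

The source may report more compounds than this note shows. Statements on the series, on what has been measured and on what is new or still open speak of the compounds shown alone.

- Compound 1 `CCSc1ccc(-c2cncnc2-c2cc(OC)c(OC)c(OC)c2)cc1` gives 1030 nM
- Compound 2 `COc1cc(-c2ncncc2-c2ccc(OC(C)C)cc2)cc(OC)c1OC` gives 9970 nM

In a functional assay on SiHa cells (Homo sapiens) for antiproliferative activity, read by CCK-8 assay, with a stated time of 72 h (on this read-out lower numbers stand for stronger inhibition and higher numbers for weaker inhibition), compound 2 holds the higher of the two numbers, and it is the starting point here. Compound 3 `CNC(=O)c1ccc(-c2cncnc2-c2cc(OC)c(OC)c(OC)c2)cc1` carries methylcarbamoyl in place of isopropoxy on an aromatic carbon, para to a large group. Within the data shown here, one measured step bears on this change at the same place: a 9.7-fold higher number from compound 1 to compound 2 (0.99 log units; beyond the scatter), beyond the scatter, with isopropoxy in place of ethylsulfanyl. Among the measured compounds shown here, that single step shows that this place can move the number clearly, but no measured compound carries methylcarbamoyl, so its direction does not carry over directly. With compound 2 at the top of the measured values, a modest move towards stronger inhibition is expected, with wide uncertainty. The expected step is a 2.5-fold lower number from compound 2 to compound 3 (0.40 log units; beyond the scatter). For compound 3 the estimated value is 4000 nM, with an expected range of 900 nM to 15000 nM.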

Compound 3, half-maximal inhibitory concentration: 10900 nM
For compound 3 the middle estimate is 2.7-fold (0.44 log units) below the measured one, within the range that was stated.
By their numbers in this assay, from the lowest: compound 1; then compounds 2 and 3 (each within the scatter of the next).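

In this assay, methylcarbamoyl and isopropoxy at this position, para to a large group, give numbers that cannot be told apart (a 1.1-fold higher number from compound 2 to compound 3 (0.04 log units; within the scatter)). Ethylsulfanyl now stands apart from two different replacements, one being the earlier step (a 9.7-fold higher number from compound 1 to compound 2 (0.99 log units; beyond the scatter)) and the other the new one (an 11-fold higher number from compound 1 to compound 3 (1.02 log units; beyond the scatter)), so among the three groups shown only ethylsulfanyl gives the lower number. Nothing at hand accounts for this difference between the groups.

The compounds shown leave open whether the lower number depends on the sulfur atom or on ethylsulfanyl as a whole, a question that ethoxy and methylsulfanyl at the same place would address. Also open, from the compounds shown here alone, is how a carboxylic acid or an amine there would compare with these three groups.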